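The source may report more compounds than this note shows. Statements on the series, on what has been measured and on what is new or still open speak of the compounds shown alone.

In a functional assay on MGC-803 cells (Homo sapiens) for inhibition, read by MTT assay, with a stated time of 72 h (on this read-out lower numbers stand for stronger inhibition and higher numbers for weaker inhibition), compound 1 `FC(F)(F)c1ccc(CSc2nc(N3CCNCC3)cc(C(F)(F)F)n2)cc1` gives 5870 nM, compound 2 `FC(F)(F)c1ccc(CSc2nc(Sc3nnnn3-c3ccccc3)cc(C(F)(F)F)n2)cc1` gives 12400 nM and compound 3 `Cc1nnc(Sc2cc(C(F)(F)F)nc(SCc3ccc(C(F)(F)F)cc3)n2)s1` gives 11400 nM. Compound 3 therefore lies within the scatter of both other compounds. Compound 4 `FC(F)(F)c1ccc(CSc2nc(SC3=NCCS3)cc(C(F)(F)F)n2)cc1` differs from compound 3 by a group of 5 heavy atoms (3 carbon, 1 nitrogen, 1 sulfur; one five-membered non-aromatic ring with 2 hetero atoms) in place of a group of 6 heavy atoms (3 carbon, 2 nitrogen, 1 sulfur; one five-membered aromatic ring with 3 hetero atoms), on a sulfur. Among the compounds with values here, the closest precedent is the other change on a sulfur, a 1.1-fold lower number from compound 2 to compound 3 (0.04 log units; within the scatter). The change on an aromatic carbon, a 1.9-fold higher number from compound 1 to compound 3 (0.29 log units; within the scatter), also stays within the scatter. Neither step tests a non-aromatic ring on a sulfur, so the expectation is tentative: no step beyond the scatter in this assay. The value estimated for compound 4 is 10000 nM, with an expected range of 4500 nM to 22000 nM. This corresponds to an expected step of a 1.1-fold lower number from compound 3 to compound 4 (0.06 log units; within the scatter).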

Compound 4, half-maximal inhibitory concentration: 24500 nM
Estimate against measurement, compound 4: 2.5-fold (0.39 log units) below, and the stated range ends below it.
By their numbers in this assay, from the lowest: compounds 1, 3, 2 and 4 (each within the scatter of the next, the first and the last beyond it).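

Within the data shown here, on a sulfur, replacing 5-methyl-1,3,4-thiadiazol-2-yl with the non-aromatic five-membered ring gives the first step beyond the scatter at this place in this assay (a 2.1-fold higher number from compound 3 to compound 4 (0.33 log units; beyond the scatter)), though only a modest one. Replacing the larger 1-phenyl-1H-tetrazol-5-yl with the same ring stays within the scatter (a 2.0-fold higher number from compound 2 to compound 4 (0.30 log units; within the scatter)). On an aromatic carbon, the sulfur-linked ring in place of piperazin-1-yl gives a wider modest step (a 4.2-fold higher number from compound 1 to compound 4 (0.62 log units; beyond the scatter)).

Going by these compounds, the effect of a basic-free open chain such as 2-hydroxyethyl or an amine such as 2-aminoethyl on this sulfur remains open. Nothing available here explains these steps.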